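Swapping iodo for fluoro on a cytotoxic compound

The compounds below may be only part of what the source reports. "The series", "measured", "known", "first", "only" and "open" are said of these compounds alone.

Compound 1 (`C/C(=N\NC(=S)Nc1ccc(I)cc1)c1ccccn1`) gives 64 nM
Compound 2 (`C/C(=N/NC(=S)Nc1ccc(Cl)cc1)c1ccccn1`) gives 5.9 nM
Compound 3 (`C/C(=N\NC(=S)Nc1ccc(F)cc1)c1ccccn1`) is not yet measured

In a functional assay on T98G cells (Homo sapiens) for cytotoxicity, read by MTT assay, with a stated time of 48 h (a higher number here means a weaker inhibitor, a lower number a stronger inhibitor), compound 1 has the higher of the two measured numbers (64 nM) and so is the weaker inhibitor, while compound 2 gives a lower number (5.9 nM) by a margin beyond the usual scatter. Compound 3 keeps the core of compound 1 and changes a single group (fluoro in place of iodo on an aromatic carbon): fluoro in place of iodo on an aromatic carbon, para to a large group. For the measured compounds named here, no measured pair shows this swap alone, so the data give no direct size for it. Going by the values given here, the only other guide is compound 2 (5.9 nM), whose number lies lower, so a moderate step toward a lower number in this assay is expected, probably beyond the scatter. The estimate amounts to an expected change (a 3.2-fold lower number from compound 1 to compound 3 (0.51 log units; beyond the scatter)). Compound 3 is estimated at 20 nM (expected range 5 nM to 80 nM).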

Compound 3, half-maximal inhibitory concentration: 17 nM
Compound 3: the middle estimate sits 1.2-fold (0.07 log units) above what was measured; measured number inside the range.
By their numbers in this assay, from the lowest: compound 2; then compound 3; then compound 1.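

In this assay, with the shared core held fixed, fluoro in place of iodo on an aromatic carbon, para to a large group, gives a 3.8-fold lower number from compound 1 to compound 3 (0.58 log units; beyond the scatter), the first direct size for a change at this position. The step is modest but lies beyond the scatter, so the position is sensitive to which halogen it carries, even though the two groups match in heavy-atom count and neither adds a ring, a hydrogen-bond donor or acceptor, or a charge. Nothing available here explains why the number moves in this direction.

Compound 2 differs from compound 3 in more than one place, so it cannot show what chloro alone does here. Going by these compounds, how a plain hydrogen, a methoxy group or an amine at this position would compare remains open.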